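The source may report more compounds than this note shows. Statements on the series, on what has been measured and on what is new or still open speak of the compounds shown alone.

Compound 1, with the structure `C=CCn1c(=O)/c(=C\c2ccc(Cl)c(Cl)c2)[nH]c(=O)/c1=C\c1ccccc1OC`, is reported in a functional assay on HL-60 cells (Homo sapiens) for cytotoxicity, read by CCK-8 assay, with a stated time of 72 h (a higher number here means a weaker inhibitor, a lower number a stronger inhibitor), as "not active" (no number reported), without a number attached. Going by the values given here, compound 2, with the structure `C=CCn1c(=O)/c(=C\c2cc(F)ccc2C)[nH]c(=O)/c1=C\c1ccccc1OC`, gives 2600 nM in this assay and is therefore the only compound in this set that carries a single number, the other entry having none. Compound 3, with the structure `C=CCn1c(=O)/c(=C\c2cccc(C)c2)[nH]c(=O)/c1=C\c1ccccc1OC`, has not yet been measured. Compound 3 differs from compound 2 in one place: 3-methylphenyl in place of 5-fluoro-2-methylphenyl on a double-bonded chain carbon bound to an aromatic carbon. Among the compounds with values here, no step between two measured compounds is available to calibrate this change, so the expected step in this assay from compound 2 to compound 3 is taken as a 1.3-fold higher number from compound 2 to compound 3 (0.13 log units; within the scatter), a small weakening that may well sit within the usual scatter. On that basis compound 3 is estimated to give 3500 nM in this assay, with a plausible range from 1200 nM to 10000 nM.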

Compound 3, half-maximal inhibitory concentration: 16700 nM
Compound 3: middle estimate off by 4.8-fold (0.68 log units), on the low side; measured number outside the range, above it.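

In this assay, going by these compounds alone, the exchange of 5-fluoro-2-methylphenyl for 3-methylphenyl on a double-bonded chain carbon bound to an aromatic carbon gives a 6.4-fold higher number from compound 2 to compound 3 (0.81 log units; beyond the scatter) and so supplies the first readable step in this set. It shows that this position responds to the substituents on its aromatic group, even when both groups are a six-membered aromatic ring of carbon only, with no hydrogen-bond donors or acceptors. Nothing available speaks to why the number moves.

The compounds shown leave open whether the loss of the fluorine or the change in the methyl group carries the step, and compound 1 has no number from which a step could be read. They also leave open how this position would respond to an aromatic ring bearing an amine or a carboxylic acid.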